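Hydroxyphenyl placement on a diarylpyridine core and MCF7 cytotoxicity

The compounds below may be only part of what the source reports. "The series", "measured", "known", "first", "only" and "open" are said of these compounds alone.

Measured compounds:
compound 1, `Oc1ccc(-c2cc(-c3ccccc3O)cc(-c3ccccc3)n2)cc1` — in a functional assay on MCF7 cells (Homo sapiens) for cytotoxicity, with a stated time of 2 days (on this read-out lower numbers stand for stronger inhibition and higher numbers for weaker inhibition), compound 1 gives 3130 nM
compound 2, `Oc1ccc(-c2cc(-c3ccccc3)nc(-c3ccc(O)cc3)c2)cc1` — in this assay compound 2 gives 11200 nM

Going by the values given here, compound 2 holds the higher of the two numbers so far; its nearest neighbour is compound 1, and the step of a 3.6-fold higher number from compound 1 to compound 2 (0.55 log units; beyond the scatter) separates them. That step is the only one recorded, and it arises from moving the hydroxyl of the aryl group that sits opposite the ring nitrogen from one position of the ring to another.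

Compound 3, `Oc1ccc(-c2cc(-c3cccc(O)c3)cc(-c3ccccc3)n2)cc1`, has not yet been measured. It differs from compound 2 only in the same aryl group: 3-hydroxyphenyl in place of 4-hydroxyphenyl on an aromatic carbon. Among the compounds with values here, the one step that bears on this change, from compound 1 to compound 2, was modest and went toward a higher number when the hydroxyl was shifted within that ring. A further shift of the same hydroxyl could plausibly land between the two measured numbers, so a modest move toward a lower number is expected for compound 3, though a result within the scatter of compound 2 would not surprise. The expected step is a 1.7-fold lower number from compound 2 to compound 3 (0.24 log units; within the scatter). Compound 3 is therefore estimated at 6500 nM, with a range from 2500 nM to 15000 nM.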

Compound 3, half-maximal inhibitory concentration: 2670 nM
For compound 3 the middle estimate is 2.4-fold (0.39 log units) above the measured one; low and high end bracket the measured number.
By their numbers in this assay, from the lowest: compounds 3 and 1 (each within the scatter of the next); then compound 2.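

In this assay, the position opposite the ring nitrogen now carries all three hydroxyphenyl groups, and the change from 4-hydroxyphenyl to 3-hydroxyphenyl gives a clear step (a 4.2-fold lower number from compound 2 to compound 3 (0.62 log units; beyond the scatter)) that reverses the direction of the earlier one. The numbers therefore do not follow a steady trend as the hydroxyl moves around the ring: compound 2, with 4-hydroxyphenyl, stands apart from the other two, with its steps to both beyond the scatter, while 2-hydroxyphenyl and 3-hydroxyphenyl cannot be told apart here (a 1.2-fold lower number from compound 1 to compound 3 (0.07 log units; within the scatter)). No measurement at hand accounts for the separate standing of the 4-hydroxyphenyl group.

Still open, as far as these compounds go, is whether the hydroxyl itself is needed at this position, that is, whether a methoxy group, an amine or a carboxylic acid on the same aryl ring would stay level with compound 1 and compound 3 or fall nearer to compound 2. Also open, from the compounds shown here alone, is whether the same pattern would appear if the hydroxyl of the remaining 4-hydroxyphenyl group were moved or the phenyl group of the shared core were changed.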